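Series notes: five-membered ring amide in place of chain amide

This account rests on a few compounds, and the source may have more. Where it says the series, first, only, none or still open, it means among the compounds named here.

Measured compounds:
compound 1 `FC(F)(F)c1nn(-c2ccc3ncccc3c2)c2nc(Nc3cnn(C4CCNCC4)c3)ncc12` — "nd" (no result reported) in an assay on SK-OV-3 cells for inhibition of eIF-2-alpha kinase GCN2 (Homo sapiens); a lower number here means a stronger inhibitor, a higher number a weaker inhibitor
compound 2 `COCCNC(=O)CNc1ncc2c(Br)nn(-c3ccc4ncccc4c3)c2n1` — "nd" (no result reported) in this assay
compound 3 `COCCNC(=O)[C@H]1C[C@H](Nc2ncc3c(Br)nn(-c4ccc5ncccc5c4)c3n2)C1` — 86 nM in this assay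

Compound 2 has no single number in this assay; compound 1 likewise has none, so the only figure available is that of compound 3, for which compound 3 gives 86 nM. The step from compound 2 to compound 4 `CNC(=O)[C@@H]1CC[C@@H](Nc2ncc3c(Br)nn(-c4ccc5ncccc5c4)c3n2)C1` is a group of 9 heavy atoms (7 carbon, 1 nitrogen, 1 oxygen; one five-membered non-aromatic ring of carbon only) in place of a group of 8 heavy atoms (5 carbon, 1 nitrogen, 2 oxygen; no ring), on a nitrogen on an aromatic ring. For the measured compounds named here, no measured pair bears on this change, so no direction can be read from the data; the change is therefore treated as neutral within scatter. Compound 3, which carries an amide on a ring on the same nitrogen, gives 86 nM, and compound 4 is expected to come out near it, estimated at 80 nM with a range of 25 nM to 250 nM.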

Compound 4, half-maximal inhibitory concentration: 25 nM
Compound 4: the middle estimate sits 3.2-fold (0.51 log units) above what was measured; low and high end bracket the measured number.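

In this assay no step can be read from compound 2 to compound 4, and nothing shown explains the result of compound 4. The compounds shown leave open how the ((2-methoxyethyl)carbamoyl)methyl group and the five-membered ring group compare on the shared core.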